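A few compounds are considered here, and "the series" means these few. Any claim that something is new, unique, unknown or untested is made for them only; others in the source may bear on it.

Working notes on the series. The shared core is a cinnamic acid bearing a methoxy group and a prenyl chain, with a triazolylmethyl ether carrying an aryl group on the triazole nitrogen. Compound 1 `COc1ccc(/C=C\C(=O)O)c(OCc2cn(-c3ccccc3C(=O)N3CCC(O)C3)nn2)c1CC=C(C)C` and compound 2 `COc1ccc(/C=C\C(=O)O)c(OCc2cn(-c3ccccc3I)nn2)c1CC=C(C)C` differ only in the substituent on that aryl ring. In a functional assay on A-431 cells (Homo sapiens) for cytotoxicity, read by MTT assay, with a stated time of 24 h (a higher number here means a weaker inhibitor, a lower number a stronger inhibitor), compound 1 gives 31500 nM and compound 2 gives 32700 nM; the step of a 1.0-fold higher number from compound 1 to compound 2 (0.02 log units; within the scatter) shows that exchanging the (3-hydroxypyrrolidin-1-yl)carbonyl group for iodo leaves the read-out essentially unchanged. Compound 3 `COc1ccc(-n2cc(COc3c(/C=C\C(=O)O)ccc(OC)c3CC=C(C)C)nn2)cc1` carries a 4-methoxyphenyl on the triazole; in this assay compound 3 gives "not determined" (no result reported), so it stands nowhere on the numbers shown.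

Compound 4 `COc1ccc(/C=C\C(=O)O)c(OCc2cn(-c3ccccc3)nn2)c1CC=C(C)C` is the unsubstituted phenyl analogue. The change from compound 3 to compound 4 is hydrogen in place of methoxy on an aromatic carbon. For the measured compounds named here, no measured step addresses this exact change. Going by the values given here, the only measured step, a 1.0-fold higher number from compound 1 to compound 2 (0.02 log units; within the scatter), concerns a different position on the same aryl ring and lies within the scatter; it suggests that substituents on this ring move the number little, but it is one pair only and does not cover the 4-methoxyphenyl-to-phenyl exchange. No step beyond the scatter is therefore expected for compound 4, and the number is expected near the values of compounds 1 and 2. Compound 4 is estimated at 30000 nM, in the range 10000 nM to 90000 nM.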

Compound 4, half-maximal inhibitory concentration: 21200 nM
The estimate for compound 4 lay 1.4-fold (0.15 log units) above the measured number; measured number inside the range.
By their numbers in this assay, from the lowest: compounds 4, 1 and 2 (each within the scatter of the next).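

With compound 4, the aryl ring on the triazole now has a member with no substituent at the position varied in compounds 1 and 2, so the earlier exchange of one group for another gains a reference point. In this assay, hydrogen in place of iodo gives a 1.5-fold lower number from compound 2 to compound 4 (0.19 log units; within the scatter), and hydrogen in place of the (3-hydroxypyrrolidin-1-yl)carbonyl group gives a 1.5-fold lower number from compound 1 to compound 4 (0.17 log units; within the scatter), so neither group can be told apart from hydrogen on these numbers, and compounds 1, 2 and 4 form a single group within the scatter. The exchange of 4-methoxyphenyl for phenyl itself cannot be read, as compound 3 has no result in this assay, and nothing available accounts for the flat response of the three compounds.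

The compounds shown leave open whether a methoxy group on this ring has any effect on the number, and whether an amine or a carboxylic acid on the ring would give a step beyond the scatter. They also leave open whether the flat response extends to other parts of the shared core, for example a longer chain in place of the prenyl chain or a methyl ester in place of the carboxylic acid.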